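The source may report more compounds than this note shows. Statements on the series, on what has been measured and on what is new or still open speak of the compounds shown alone.

Compound 1 `COc1ccc2cc(C(C)c3nnc4n3N=C(c3ccc(Br)cc3)CS4)ccc2c1` gives 11500 nM in a functional assay on MCF7 cells (Homo sapiens) for inhibition, read by sulforhodamine B assay, with a stated time of 72 h; on this read-out higher numbers stand for weaker inhibition and lower numbers for stronger inhibition. Compound 2 `CC(c1ccc(-c2ccccc2)c(F)c1)c1nnc2n1N=C(c1ccc(Cl)cc1Cl)CS2` gives 7600 nM.

Compound 2 has the lower of the two numbers, yet compound 1 lies within the usual scatter of it, so the two cannot be told apart. Compound 3 `COc1ccc(C2=Nn3c(nnc3C(C)c3ccc(-c4ccccc4)c(F)c3)SC2)cc1` differs from compound 2 in one place: 4-methoxyphenyl in place of 2,4-dichlorophenyl on a carbon with a double bond to nitrogen. Within the data shown here, no step between measured compounds is known, so the change itself is the only guide; a small shift in this assay is expected, quite possibly none beyond the scatter. For compound 3 the expected value is 10000 nM, within 4000 nM to 30000 nM. This expectation amounts to a 1.3-fold higher number from compound 2 to compound 3 (0.12 log units; within the scatter).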

Compound 3, half-maximal inhibitory concentration: 2600 nM
The estimate for compound 3 lay 3.8-fold (0.59 log units) above the measured number; the measured number lies below the stated range.
By their numbers in this assay, from the lowest: compound 3; then compounds 2 and 1 (each within the scatter of the next).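

Within this assay the group on this carbon with a double bond to nitrogen clearly counts, something compounds 1 and 2 could not show: 4-methoxyphenyl in place of 2,4-dichlorophenyl gives a 2.9-fold lower number from compound 2 to compound 3 (0.47 log units; beyond the scatter) while the heavy-atom count stays the same. The entering group also brings one hydrogen-bond acceptor, where the leaving group has none. Nothing available explains the step.

As far as these compounds go, whether it follows from gaining the methoxy group or from losing the two chlorines stays open. A plain phenyl or a 4-aminophenyl at this position would help separate the two.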